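Adding a nitro group to the benzoyl of compound 3

A few compounds are considered here, and "the series" means these few. Any claim that something is new, unique, unknown or untested is made for them only; others in the source may bear on it.

Of the compounds shown here, three sharing one core have been tested in a functional assay on RAW264.7 cells (Mus musculus) for inhibition, read by Griess assay, with stated times of 3 h and 24 h; a lower number here means a stronger inhibitor, a higher number a weaker inhibitor. Compound 1 `C=C1CC[C@H]2[C@@](C)(CCC(=O)N[C@@]2(C)CO)[C@@H]1/C=C/C1=CCOC1=O` keeps a hydrogen on an oxygen on a saturated carbon. Compound 1 gives > 50000 nM, which is a limit and not a number. Compound 2 `C=C1CC[C@H]2[C@@](C)(CCC(=O)N[C@@]2(C)COC(=O)c2cccnc2)[C@@H]1/C=C/C1=CCOC1=O` has (pyridin-3-yl)carbonyl in that place. Compound 2 gives > 50000 nM, again a limit. Compound 3 `C=C1CC[C@H]2[C@@](C)(CCC(=O)N[C@@]2(C)COC(=O)c2ccccc2)[C@@H]1/C=C/C1=CCOC1=O` has benzoyl there instead. Compound 3 gives > 50000 nM, also a limit. Compound 3 therefore has no exact position on the scale, and it stands with the other two at the limit of > 50000 nM in this assay, at which 3 of the 3 values shown sit.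

Compound 4 `C=C1CC[C@H]2[C@@](C)(CCC(=O)N[C@@]2(C)COC(=O)c2ccc([N+](=O)[O-])cc2)[C@@H]1/C=C/C1=CCOC1=O` is compound 3 with one change: nitro in place of hydrogen on an aromatic carbon. In words, nitro replaces hydrogen on an aromatic carbon, para to a large group.

Among the measured compounds shown here, three measured steps bear on this: a step that the two limits leave unreadable from compound 1 to compound 2, a step that the two limits leave unreadable from compound 1 to compound 3 and a step that the two limits leave unreadable from compound 2 to compound 3. The last is the closest, since it also alters the group on the carbonyl carbon. None of them has a readable size, so they support no direction. The likeliest result is another limit, and the expected change is only a number no higher from compound 3 to compound 4 (the limit leaves the size open). For compound 4 the estimate is 50000 nM, with an expected range from 20000 nM to 100000 nM.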

Compound 4, half-maximal inhibitory concentration: 33500 nM
Estimate against measurement, compound 4: 1.5-fold (0.17 log units) above, and the stated range covers the measured number.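

In this assay, among the compounds shown here, compound 4 gives 33500 nM, the first exact number in this small set, so an aromatic carbon para to a large group is the first place where a change yields a readable value: the limit of > 50000 nM in this assay, at which 3 of the 4 values shown sit. For the compounds shown here, putting nitro in place of hydrogen there gives an at least 1.4-fold lower number from compound 3 to compound 4 (0.17 log units; that floor lies within the scatter), and compound 4 also compares with the other two as an at least 1.4-fold lower number from compound 2 to compound 4 (0.17 log units; that floor lies within the scatter) and as an at least 1.4-fold lower number from compound 1 to compound 4 (0.17 log units; that floor lies within the scatter), while the earlier steps among compounds 1, 2 and 3 cannot be read. All three new steps are floors that lie within the scatter, so they show that compound 4 can be placed on the scale, not that nitro brings a real gain in inhibition.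

From the compounds shown here alone, the true size of the step stays open, as compound 3 has only a limit and no exact number. Also open, going by these compounds, is whether another group at the same place, such as an amine, a methoxy group or a carboxylic acid, would give a readable value too, or whether one on a different carbon of the ring would.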